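From 4-carboxyphenyl to 4-methyl-2-nitrophenyl

This account rests on a few compounds, and the source may have more. Where it says the series, first, only, none or still open, it means among the compounds named here.

Compounds in a functional assay on ileum (Cavia porcellus) for antagonist activity; on this read-out lower numbers stand for stronger inhibition and higher numbers for weaker inhibition:
Compound 1 `N#Cc1ccc(OCCCOc2ccc3c(O)c([N+](=O)[O-])c(=O)oc3c2)cc1`: > 10000 nM
Compound 2 `O=C(O)c1ccc(OCCCOc2ccc3c(O)c([N+](=O)[O-])c(=O)oc3c2)cc1`: > 20000 nM
Compound 3 `Cc1ccc(OCCCOc2ccc3c(O)c([N+](=O)[O-])c(=O)oc3c2)c([N+](=O)[O-])c1`: not yet measured

Compound 2 stands only at a limit of this assay, > 20000 nM. Compound 1 also gives only a limit, > 10000 nM. The change now followed is 4-methyl-2-nitrophenyl in place of 4-carboxyphenyl on an oxygen on a saturated carbon, with 4-methyl-2-nitrophenyl in place of 4-carboxyphenyl on an oxygen on a saturated carbon. Among the compounds with values here, the one measured step that bears on it is a step that the two limits leave unreadable from compound 1 to compound 2, carboxy in place of cyano on an aromatic carbon, so it offers no size to carry over. With no number yet in this assay, only a modest move towards stronger inhibition is expected, and another limit remains quite likely. The expected step is an at least 2.5-fold lower number from compound 2 to compound 3 (0.39 log units; beyond the scatter), an estimate resting on limits alone. For compound 3 the estimated value is 8000 nM, with an expected range of 1500 nM to 30000 nM.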

Compound 3, half-maximal inhibitory concentration: > 10000 nM
Compound 3 gave a limit, no number; the forecaster's own chance of this, stated with the estimate: 55%; middle value at least 1.2-fold (0.09 log units) away from the limit.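

In this assay compound 3 gives only a limit, > 10000 nM, so its steps from compound 1 and from compound 2 cannot be read. The compounds shown leave open how compound 1, compound 2 and compound 3 actually compare in this assay, since none of them has a measured number.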